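The source may report more compounds than this note shows. Statements on the series, on what has been measured and on what is new or still open speak of the compounds shown alone.

Measured compounds:
compound 1, `CCn1c(C(=O)NCCCN(C)C)ccc1C(CC)(CC)c1ccc(OCC(=O)C(C)(C)C)c(C)c1`, with 96 nM in an assay on HL-60 cells for agonist activity at vitamin D3 receptor (Homo sapiens), read by microscopy, with a stated time of 96 h; a higher number here means that more compound is needed for the effect, a lower number that less compound is needed
compound 2, `CCn1c(C(=O)Nc2cccc(C(F)(F)F)c2)ccc1C(CC)(CC)c1ccc(OCC(=O)C(C)(C)C)c(C)c1`, with > 50000 nM in this assay

Compound 2 sits at the limit of this assay: its value, > 50000 nM, is a limit and not a number, as the limit of > 50000 nM in this assay, at which 1 of the 2 values shown sits, records. For the measured compounds named here, the one measured step, an at least 520-fold higher number from compound 1 to compound 2 (2.71 log units; beyond the scatter), is therefore itself bounded only from one side.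

Compound 3, `CCn1c(C(=O)OCc2ccc(F)cc2)ccc1C(CC)(CC)c1ccc(OCC(=O)C(C)(C)C)c(C)c1`, is not yet measured in this assay. It differs from compound 2 by (4-fluorobenzyl)oxy in place of (3-(trifluoromethyl)phenyl)amino on a carbonyl carbon. Going by the values given here, no measured pair shows this kind of exchange, so the expectation for compound 3 can only be set against where compound 2 stands and against the step from compound 1. Both compound 2 and compound 3 lack the 3-(dimethylamino)propyl group of compound 1, and the loss of that group coincided with the large step of an at least 520-fold higher number from compound 1 to compound 2 (2.71 log units; beyond the scatter).

Compound 3 is therefore expected to remain weak in this assay, with an estimate of 30000 nM (range 3000 nM to 100000 nM). The expected step of an at least 1.6-fold lower number from compound 2 to compound 3 (0.22 log units; that floor lies within the scatter) is thus no move beyond the scatter away from the limit, and a limit read-out is considered the most likely outcome for compound 3.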

Compound 3, half-maximal effective concentration: 9500 nM
Compound 3: middle estimate off by 3.2-fold (0.50 log units), on the high side; the measured number falls inside the stated range.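

In this assay, (4-fluorobenzyl)oxy in place of (3-(dimethylamino)propyl)amino on a carbonyl carbon gives a 99-fold higher number from compound 1 to compound 3 (2.00 log units; beyond the scatter), so a compound without the 3-(dimethylamino)propyl group now has a real number here, and compound 1 still needs the least compound of the three. The result also shows that this carbonyl carbon does not treat all such replacements alike, as (4-fluorobenzyl)oxy in place of (3-(trifluoromethyl)phenyl)amino gives an at least 5.2-fold lower number from compound 2 to compound 3 (0.72 log units; beyond the scatter). The true size of that step stays unknown, as it is bounded from one side only and the value of compound 2 is a limit and not a number: the limit of > 50000 nM in this assay, at which 1 of the 3 values shown sits.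

Compound 3 exchanges the linking nitrogen with its amide hydrogen and the attached aryl group in one change, so these compounds cannot separate the part played by the oxygen link from that of the 4-fluorobenzyl group. They also leave open how a 4-fluorobenzyl amide, an ester carrying the 3-(dimethylamino)propyl chain, or a primary amine in place of the dimethylamino group would read.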